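Thermodynamic Solubility: From Fluorophenyl to Pyridin-2-yl

The source may report more compounds than this note shows. Statements on the series, on what has been measured and on what is new or still open speak of the compounds shown alone.

Measured compounds:
compound 1, `CCCOc1ccc(C[C@@H](Cc2ccccc2)C(=O)O)cc1CNC(=O)c1ccc(-c2ccccc2)cc1`: < 1 ug/mL
compound 2, `CCCOc1ccc(C[C@@H](Cc2ccccc2)C(=O)O)cc1CNC(=O)c1ccc(-c2ccncc2)cc1`: 34.1 ug/mL
compound 3, `CCCOc1ccc(C[C@@H](Cc2ccccc2)C(=O)O)cc1CNC(=O)c1ccc(-c2cccc(F)c2)cc1`: < 1 ug/mL

In a physicochemical assay for solubility, read by HPLC, in phosphate buffer, measured as thermodynamic solubility, with a stated time of 48 h, at pH 7.2 (on this read-out lower numbers stand for lower solubility and higher numbers for higher solubility), compound 3 gives < 1 ug/mL, which is a limit of the assay and not a number. Compound 1 gives < 1 ug/mL, likewise a limit. Compound 3 thus stands at the limit of < 1 ug/mL in this assay, at which 2 of the 3 values shown sit. For the measured compounds named here, compound 2 gives 34.1 ug/mL, the only numerical value among the three.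

Compound 4, `CCCOc1ccc(C[C@@H](Cc2ccccc2)C(=O)O)cc1CNC(=O)c1ccc(-c2ccccn2)cc1`, differs from compound 3 by pyridin-2-yl in place of 3-fluorophenyl on an aromatic carbon. The step that bears most directly on this change is an at least 34-fold lower number from compound 2 to compound 3 (1.53 log units; beyond the scatter), and the step of an at least 34-fold higher number from compound 1 to compound 2 (1.53 log units; beyond the scatter) points the same way: replacing an all-carbon ring by a pyridine ring went with a large gain. The step that the two limits leave unreadable from compound 1 to compound 3 gives no usable size. Going back from a fluorophenyl to a pyridine ring, here with the nitrogen in the 2-position, a large rise is therefore expected, an at least 12-fold higher number from compound 3 to compound 4 (1.07 log units; beyond the scatter). Compound 4 is estimated at 12 ug/mL in this assay, within a range of 2 ug/mL to 45 ug/mL.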

Compound 4, solubility: 17 ug/mL
Compound 4: the middle estimate sits 1.4-fold (0.15 log units) below what was measured; low and high end bracket the measured number.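

In this assay, pyridin-2-yl in place of 3-fluorophenyl gives an at least 17-fold higher number from compound 3 to compound 4 (1.23 log units; beyond the scatter), and pyridin-2-yl in place of phenyl gives an at least 17-fold higher number from compound 1 to compound 4 (1.23 log units; beyond the scatter), so the large step seen earlier with pyridin-4-yl also appears with a second pyridine ring. The nitrogen's place within that ring makes no readable difference here, since pyridin-2-yl in place of pyridin-4-yl gives a 2.0-fold lower number from compound 2 to compound 4 (0.30 log units; within the scatter). Compound 1 and compound 3, the two with an all-carbon ring at this position, both remain at a limit of the assay rather than a number: the limit of < 1 ug/mL in this assay, at which 2 of the 4 values shown sit.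

Going by these compounds, whether pyridin-3-yl or a phenyl ring carrying an amine in this same place would join the two pyridine compounds stays open. So does whether a carboxylic acid on that ring would move the read-out at all.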